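The source may hold more compounds than are shown below. What is called first, only, known or untested is meant among the compounds shown, and "the series" means these compounds.

Measured so far:
compound 1 `COC(=O)N1CC2CNCC2C1` — 85%
compound 2 `O=C(c1ccco1)[C@H]1C[C@@H]2CNC[C@@H](C2)C1` — "not determined" (no result reported)
compound 3 `CNC(=O)[C@H]1C[C@@H]2CNC[C@@H](C2)C1` — 5%

Three compounds were examined in an assay on CHO cells for agonist activity at Neuronal acetylcholine receptor; alpha3/beta4 (Homo sapiens), read by FLIPR and calcium flux (on this read-out lower numbers stand for smaller maximal responses and higher numbers for larger maximal responses), and two of them gave a number. Compound 1 `COC(=O)N1CC2CNCC2C1` reaches 85% in this assay, a large maximal response. For compound 2 `O=C(c1ccco1)[C@H]1C[C@@H]2CNC[C@@H](C2)C1` no result was reported in this assay. Compound 3 `CNC(=O)[C@H]1C[C@@H]2CNC[C@@H](C2)C1` gives 5% in this assay, which is the lowest of the two numbers and lies far under compound 1, a gap beyond the usual scatter of this kind of measurement. Compound 3 therefore stands as a compound with almost no maximal response on this read-out.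

The next compound, compound 4 `CC(C)NC(=O)[C@H]1C[C@@H]2CNC[C@@H](C2)C1`, has not yet been tested in this assay. It differs from compound 3 in one place: isopropyl in place of methyl on an amide-type nitrogen. Within the data shown here, no measured pair of compounds shows what such a change does on this read-out, so there is no directly comparable step to lean on.

Given that compound 3 shows 5% in this assay, a small step is expected, most likely none beyond the scatter, with the maximal response for compound 4 staying low; the expected step is a number 7 percentage points higher from compound 3 to compound 4 (within the scatter). The estimate for compound 4 in this assay is 12%, within a range from 0% to 40%.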

Compound 4, largest response reached (Emax), in percent of the reference or control that the assay uses: 25%
Compound 4: the middle estimate sits 13 percentage points below what was measured, within the range that was stated.
By their numbers in this assay, from the lowest: compound 3; then compound 4; then compound 1.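

Swapping methyl for isopropyl on the amide-type nitrogen gives the first measured step at this position: in this assay, the change produces a number 20 percentage points higher from compound 3 to compound 4 (beyond the scatter) and counts as modest. Among these compounds, the maximal response therefore shifts measurably with the group on this nitrogen, which the earlier compounds could not show because none of them formed a pair differing in one place. No measurement shown here gives a reason for the step.

From the compounds shown here alone, a single step between two small carbon groups cannot show a trend, so it remains open whether a longer chain such as n-butyl, or a ring such as cyclopropyl, on the same nitrogen would raise the maximal response further, leave it unchanged or lower it. It is also unknown how a group of a different kind, such as a chain ending in an amine or a carboxylic acid, would behave at this position on the shared core.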